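The source may hold more compounds than are shown below. What is called first, only, known or untested is meant among the compounds shown, and "the series" means these compounds.

Measured compounds:
compound 1 `Cc1cncc(-c2ccc3[nH]c(=O)nc(-c4ccccc4)c3c2)c1` — > 50000 nM
compound 2 `O=c1nc(-c2ccccc2)c2cc(-c3cnc4ccccc4c3)ccc2[nH]1` — > 50000 nM
compound 3 `O=c1nc(-c2ccccc2)c2ccc(-c3cccnc3)cc2[nH]1` — > 50000 nM

In an ADME assay on THP-1 cells (Homo sapiens) for cytotoxicity, read by MTT assay, with a stated time of 72 h (a higher number here means that more compound is needed for the effect, a lower number that less compound is needed), compound 1 gives > 50000 nM, which is a limit of the assay and not a number. Compound 2 gives > 50000 nM, also a limit. Compound 3 gives > 50000 nM, again a limit. For the measured compounds named here, the whole measured set is therefore described by the limit of > 50000 nM in this assay, at which 3 of the 3 values shown sit, and no step between measured compounds can be sized, so compound 1 stands only at that limit, with nothing to rank it against the others.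

Compound 4 `O=c1nc(-c2ccccc2)c2cc(N3CCNCC3)ccc2[nH]1` has not yet been measured. Relative to compound 1 the change is piperazin-1-yl in place of 5-methylpyridin-3-yl on an aromatic carbon.

With every measured value sitting at the limit, no step beyond the scatter is expected in this assay, in either direction. The estimated step is a number no higher from compound 1 to compound 4 (the limit leaves the size open). Compound 4 is expected to give 50000 nM, with a range from 20000 nM to 100000 nM, and most probably the assay will again report only a limit.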

Compound 4, half-maximal effective concentration: > 25000 nM
Compound 4: only a limit was reported (the forecaster's own chance of this, stated with the estimate: 80%); the middle value lies beyond the limit too.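

In this assay compound 4 gives > 25000 nM, a limit of the assay and not a number. For the compounds shown here, compound 1 also stands only at a limit, and no step between compound 1 and compound 4 can be read. The compounds shown leave open what concentration of any of them produces the effect in this assay.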